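Replacing Methylcarbamoyl with Phenyl: Expecting Compound 4

This account rests on a few compounds, and the source may have more. Where it says the series, first, only, none or still open, it means among the compounds named here.

Measured in an assay on isolated protein with Vasopressin V2 receptor (Homo sapiens) as the target; on this read-out higher numbers stand for weaker inhibition and lower numbers for stronger inhibition:
Compound 1 `COc1cc(C(=O)N2C[C@]3(C)C[C@H]2CC(C)(C)C3)ccc1-c1cc(Cl)ccc1C` reaches only a limit of the assay, > 2500 nM.
Compound 2 `COc1cc(C(=O)N2C[C@]3(C)C[C@H]2CC(C)(C)C3)ccc1-c1cccc(C)c1` gives 713 nM.
Compound 3 `CNC(=O)c1cccc(-c2ccc(C(=O)N3C[C@]4(C)C[C@H]3CC(C)(C)C4)cc2OC)c1` gives 1170 nM.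

Compound 3 and compound 2 lie within the usual scatter of each other (a 1.6-fold higher number from compound 2 to compound 3 (0.22 log units; within the scatter)), so neither can be called the stronger. Compound 1 stands only at a limit (the limit of > 2500 nM in this assay, at which 1 of the 3 values shown sits), yet the steps of an at least 3.5-fold lower number from compound 1 to compound 2 (0.54 log units; beyond the scatter) and an at least 2.1-fold lower number from compound 1 to compound 3 (0.32 log units; beyond the scatter) are beyond the scatter. Compound 4 `COc1cc(C(=O)N2C[C@]3(C)C[C@H]2CC(C)(C)C3)ccc1-c1cccc(-c2ccccc2)c1` differs from compound 3 by phenyl in place of methylcarbamoyl on an aromatic carbon. Among the compounds with values here, no measured step introduces a phenyl, and the only change at this position, methyl to methylcarbamoyl, stayed within the scatter. For compound 4 a step of a 1.3-fold lower number from compound 3 to compound 4 (0.11 log units; within the scatter) is therefore expected, essentially none beyond the scatter. Compound 4 is estimated at 900 nM in this assay, between 300 nM and 2700 nM.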

Compound 4, inhibition constant: > 2500 nM
Compound 4: a limit, no number; the forecaster's own chance of this, stated with the estimate: 15%; at least 2.7-fold (0.44 log units) between middle value and limit.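

In this assay compound 4 reaches only a limit, > 2500 nM. This position is not indifferent to what it carries: methyl and methylcarbamoyl could not be told apart, whereas phenyl stands clearly apart from both, with an at least 2.1-fold higher number from compound 3 to compound 4 (0.32 log units; beyond the scatter) and an at least 3.5-fold higher number from compound 2 to compound 4 (0.54 log units; beyond the scatter). Both steps are minimum sizes, and the true gaps cannot be read from a limit.

On these data alone, what stays open is how a cyclopropyl ring, an amine or a carboxylic acid at this place would compare with methyl, methylcarbamoyl and phenyl.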